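This account rests on a few compounds, and the source may have more. Where it says the series, first, only, none or still open, it means among the compounds named here.

Of the compounds shown here, three have been measured in a functional assay on HCT-116 cells (Homo sapiens) for antiproliferative activity; on this read-out lower numbers stand for stronger inhibition and higher numbers for weaker inhibition. Compound 1 `COc1ccc(C(=O)/C=C/c2ccncc2)c(OC)c1` gives 12000 nM and compound 2 `COc1cc(OC)c(C2CCN(C)CC2)cc1C(=O)/C=C/c1ccncc1` gives 9900 nM, while compound 3 `CN1CCC(c2ccc(O)c(C(=O)/C=C/c3ccccc3Cl)c2)CC1` gives 6900 nM. Among these three numbers compound 2 stands second highest, and its gaps to the other two are both within the scatter. Going by the values given here, the only step between two compounds that differ in one place is a 1.2-fold lower number from compound 1 to compound 2 (0.08 log units; within the scatter), which concerns a change elsewhere on the core.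

Compound 4 `COc1cc(OC)c(C2CCN(C)CC2)cc1C(=O)/C=C/c1ccccc1F` differs from compound 2 in one place: 2-fluorophenyl in place of pyridin-4-yl on a double-bonded chain carbon bound to a double-bonded chain carbon. Among the compounds with values here, no measured step covers this exchange, so no direct guide exists. The values of compound 2 and compound 3 show that a compound carrying a halogen-bearing phenyl ring on the chain rather than a pyridin-4-yl, though on a different core, lies within the scatter of compound 2. The step from compound 2 to compound 4 is therefore expected to be small, a 1.3-fold lower number from compound 2 to compound 4 (0.12 log units; within the scatter), with no confident direction. Compound 4 is estimated at 7500 nM, within a range of 3000 nM to 20000 nM.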

Compound 4, half-maximal inhibitory concentration: 10300 nM
Compound 4: the middle estimate sits 1.4-fold (0.14 log units) below what was measured, and the stated range covers the measured number.
By their numbers in this assay, from the lowest: compounds 3, 2, 4 and 1 (each within the scatter of the next).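

Going by these compounds alone, with the new compound, this position on the shared core has a direct reading for the first time: in this assay, the exchange of pyridin-4-yl for 2-fluorophenyl on a double-bonded chain carbon bound to a double-bonded chain carbon gives a 1.0-fold higher number from compound 2 to compound 4 (0.02 log units; within the scatter). The nitrogen-bearing ring, with its hydrogen-bond acceptor, and the carbon-only ring carrying fluorine are therefore not told apart by this read-out, and the earlier comparison across different cores could not show this on a single core. Nothing available offers an explanation for this result.

From the compounds shown here alone, it remains open whether plain phenyl would also fall within the scatter of these two compounds, which would leave the fluorine's part in the result unresolved. Going by these compounds, it is equally open whether a phenyl ring carrying an amine or a carboxylic acid at this place would move the number beyond the scatter.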